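Removing a Fluorine From a Hydroxyamino Nucleoside Analog

This account rests on a few compounds, and the source may have more. Where it says the series, first, only, none or still open, it means among the compounds named here.

Compound 1 `O=c1nc(NO)c(F)cn1[C@@H]1C[C@@H](O)[C@H](CO)O1`: 1370000 nM
Compound 2 `O=c1nc(NO)ccn1[C@@H]1C=C[C@H](CO)O1`: 3500000 nM

Of the compounds shown here, two have been measured in an ADME assay on HL-60 cells (Homo sapiens) for cytotoxicity, read by MTT assay, with a stated time of 3 days; on this read-out lower numbers stand for higher toxicity in this test and higher numbers for lower toxicity in this test. Compound 1 gives 1370000 nM, the lowest of the two numbers. Compound 2 gives 3500000 nM, which lies beyond the scatter above the lower value. The two differ in more than one place, so their gap cannot be traced to a single change.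

Compound 3 `O=c1nc(NO)ccn1[C@@H]1C[C@@H](O)[C@H](CO)O1` has not yet been measured. It differs from compound 1 by hydrogen in place of fluoro on an aromatic carbon. Among the compounds with values here, no measured pair isolates this change, so its size must be judged from the pair alone. Compound 2, which also carries hydrogen at that carbon but on a different sugar, shows the higher number, and a modest rise in that direction seems likely, though it may stay within the scatter. The expected step is a 1.5-fold higher number from compound 1 to compound 3 (0.16 log units; within the scatter). Compound 3 is estimated at 2000000 nM, with a range from 700000 nM to 6000000 nM.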

Compound 3, half-maximal cytotoxic concentration: 460000 nM
Beside the measured number, compound 3's estimate is 4.3-fold (0.64 log units) above it; measured number below the stated range.
By their numbers in this assay, from the lowest: compound 3; then compound 1; then compound 2.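

Within the data shown here, this pair gives the first clean reading of the aromatic carbon ortho to the hydroxyamino group: in this assay, hydrogen in place of fluoro gives a 3.0-fold lower number from compound 1 to compound 3 (0.47 log units; beyond the scatter), a modest step beyond the usual scatter. On this sugar, then, the compound with fluoro is the less toxic of the two in this test, and the change of a single atom at this position is enough to move the number measurably. Nothing shown here accounts for the size or direction of this step.

On these data alone, it remains open whether chloro, methyl or an amine at this carbon would give a number nearer compound 1 or compound 3. As far as these compounds go, it is also open whether the same exchange would give a step of this size on the sugar of compound 2.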